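Aryl Exchange on the Amide Nitrogen of a Dopamine Agonist Core

The source may hold more compounds than are shown below. What is called first, only, known or untested is meant among the compounds shown, and "the series" means these compounds.

Three amides sharing one core have been measured in a functional assay on HEK293 cells for agonist activity at D(4) dopamine receptor (Homo sapiens), read by FLIPR; on this read-out higher numbers stand for an effect only at larger amounts of compound and lower numbers for an effect already at smaller amounts. Compound 1 `Cc1cc(C)cc(NC(=O)CN2CCC(c3cccc[n+]3[O-])CC2)c1` gives 52 nM, compound 2 `O=C(CN1CCC(c2cccc[n+]2[O-])CC1)Nc1ccc(F)cc1` gives 85 nM, and compound 3 `CCc1cccc(NC(=O)CN2CCC(c3cccc[n+]3[O-])CC2)c1` gives 95 nM, the highest of the three numbers; its nearest neighbour is compound 2 with a 1.1-fold higher number from compound 2 to compound 3 (0.05 log units; within the scatter), its furthest compound 1 with a 1.8-fold higher number from compound 1 to compound 3 (0.26 log units; within the scatter). Compound 4 `Cc1ccc(Cl)cc1NC(=O)CN1CCC(c2cccc[n+]2[O-])CC1` differs from compound 3 in one place: 5-chloro-2-methylphenyl in place of 3-ethylphenyl on an amide-type nitrogen. Every step measured so far is an exchange of the aryl group on the amide nitrogen, and a 1.6-fold higher number from compound 1 to compound 2 (0.21 log units; within the scatter), a 1.8-fold higher number from compound 1 to compound 3 (0.26 log units; within the scatter) and a 1.1-fold higher number from compound 2 to compound 3 (0.05 log units; within the scatter) all stayed within the scatter. For compound 4 a further aryl exchange is therefore expected to give a 1.1-fold lower number from compound 3 to compound 4 (0.02 log units; within the scatter), a step within the scatter. Compound 4 is estimated at 90 nM, with a range from 40 nM to 200 nM.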

Compound 4, half-maximal effective concentration: 126 nM
Compound 4: the middle estimate sits 1.4-fold (0.15 log units) below what was measured, and the stated range covers the measured number.
By their numbers in this assay, from the lowest: compounds 1, 2, 3 and 4 (each within the scatter of the next, the first and the last beyond it).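

In this assay, 5-chloro-2-methylphenyl on the amide-type nitrogen stays within the scatter of two of the other aryl groups (a 1.3-fold higher number from compound 3 to compound 4 (0.12 log units; within the scatter); a 1.5-fold higher number from compound 2 to compound 4 (0.17 log units; within the scatter)). Against 3,5-dimethylphenyl, however, it gives the only step beyond the scatter at this position so far, and a modest one (a 2.4-fold higher number from compound 1 to compound 4 (0.38 log units; beyond the scatter)). Nothing available bears on the reason for this step. The compounds shown leave open what a carboxylic acid, an amine or a methoxy group on the aryl ring would give in this assay.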